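The source may report more compounds than this note shows. Statements on the series, on what has been measured and on what is new or still open speak of the compounds shown alone.

Values in a functional assay on A549 cells (Homo sapiens) for inhibition, read by MTT assay, with a stated time of 72 h; a higher number here means a weaker inhibitor, a lower number a stronger inhibitor:

- compound 1 `COc1cc(OC)c(C(=O)/C=C/c2ccccc2OC)c(OC)c1`: 19800 nM
- compound 2 `COc1cc(OC)c(C(=O)/C=C/c2ccc([N+](=O)[O-])cc2)c(OC)c1`: 7100 nM

Compound 2 stands lowest of the two measured compounds in this assay, and its gap to compound 1 lies beyond the scatter, which makes compound 2 the stronger inhibitor of the pair. Among the compounds with values here, only two numbers are available, so this placing says little about the series as a whole. Within the data shown here, the two compounds also differ by more than a single change, so their gap gives no measured step to carry forward.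

The next compound is compound 3 `COc1cc(OC)c(C(=O)/C=C/c2ccc(N)cc2)c(OC)c1`, which has amino in place of nitro on an aromatic carbon, para to a large group: amino in place of nitro on an aromatic carbon. Among the measured compounds shown here, no measured pair shows this change, so the expectation starts from compound 2 at 7100 nM and the range is kept wide. A small move towards a lower number is expected, with no step beyond the scatter. The expected step is a 1.4-fold lower number from compound 2 to compound 3 (0.15 log units; within the scatter). Compound 3 is estimated at 5000 nM, with an expected range of 1600 nM to 16000 nM.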

Compound 3, half-maximal inhibitory concentration: > 50000 nM
Compound 3: a limit, no number; the forecaster's own chance of this, stated with the estimate: 3%; at least 10-fold (1.00 log units) between middle value and limit.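

In this assay compound 3 gives > 50000 nM, which is a limit of the assay and not a number. Amino in place of nitro on an aromatic carbon, para to a large group, gives an at least 7.0-fold higher number from compound 2 to compound 3 (0.84 log units; beyond the scatter); this is the first measured step at this position, and it shows that the position is sensitive to the group it carries. The change of 4-aminophenyl in place of 2-methoxyphenyl gives an at least 2.5-fold higher number from compound 1 to compound 3 (0.40 log units; beyond the scatter), which puts compound 3 behind both earlier compounds, though the true size of either step cannot be read past the limit: the limit of > 50000 nM in this assay, at which 1 of the 3 values shown sits.

The compounds shown leave open how a hydrogen, a dimethylamino group or an acetamide at this position would read, and so whether the gap reflects a gain from the nitro of compound 2, a loss from the amino of compound 3, or both. From the compounds shown here alone, with a single cell line and a single read-out, it also remains open whether this order would hold in any other assay.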